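Swapping a halogenated phenyl on a urea: expected effect

The compounds below may be only part of what the source reports. "The series", "measured", "known", "first", "only" and "open" are said of these compounds alone.

Of the compounds shown here, three have been measured in a functional assay on A549 cells (Homo sapiens) for antiproliferative activity, read by MTT assay; a lower number here means a stronger inhibitor, a higher number a weaker inhibitor. Compound 1 `O=C(Nc1ccc(F)cc1)Nc1cccc(CNc2ncnc3ccccc23)c1` gives 21000 nM. Compound 2 `O=C(Nc1cccc(CNc2ncnc3ccccc23)c1)Nc1ccccc1Cl` gives 18000 nM. Compound 3 `COc1cc2ncnc(NCc3cccc(NC(=O)Nc4ccc(F)cc4)c3)c2cc1OC` gives 16900 nM. All three numbers lie within the usual scatter of one another, so none of them can be called stronger or weaker than the others.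

Compound 2 differs from compound 1 in one place: 2-chlorophenyl in place of 4-fluorophenyl on an amide-type nitrogen. This change made a 1.2-fold lower number from compound 1 to compound 2 (0.07 log units; within the scatter). The core of compound 3 differs from the core of compound 1 in more than one place, and that difference is not broken down here; the two values simply sit close together.

Compound 4 `COc1cc2ncnc(NCc3cccc(NC(=O)Nc4ccccc4Cl)c3)c2cc1OC` has not yet been measured. It differs from compound 3 in exactly the way compound 2 differs from compound 1: 2-chlorophenyl in place of 4-fluorophenyl on an amide-type nitrogen. Because the earlier instance of this change produced only a 1.2-fold lower number from compound 1 to compound 2 (0.07 log units; within the scatter), the same change on the core of compound 3 is expected to make a step of about a 1.1-fold lower number from compound 3 to compound 4 (0.05 log units; within the scatter) in this assay. That expectation rests on a single earlier pair, so the spread around it is wide. Compound 4 is estimated to give about 15000 nM in this assay, most likely somewhere between 7000 nM and 32000 nM.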

Compound 4, half-maximal inhibitory concentration: 15200 nM
Compound 4: middle estimate off by 1.0-fold (0.01 log units), on the low side, and the stated range covers the measured number.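

In this assay, putting 2-chlorophenyl in place of 4-fluorophenyl on an amide-type nitrogen gives a 1.1-fold lower number from compound 3 to compound 4 (0.05 log units; within the scatter), so on this core too the swap leaves the reading within the usual scatter of repeated measurements. Set side by side, the two steps agree as closely as such measurements can show: the same change on two cores in this assay, a 1.2-fold lower number (0.07 log units; within the scatter) from compound 1 to compound 2 and a 1.1-fold lower number (0.05 log units; within the scatter) from compound 3 to compound 4, 1.0-fold (0.02 log units) apart, within the scatter of two such steps. This shows that on these two cores the swap behaves alike, with no readable effect on either, but it does not show that a change with a real effect would carry over in the same way, and two cores say nothing about any other core in the series.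

The compounds shown carry only 4-fluorophenyl and 2-chlorophenyl at this place, which leaves open whether a quite different group there, such as an unsubstituted alkyl chain, a longer chain ending in an amine, or a phenyl bearing a carboxylic acid, would move the number beyond the scatter. As far as these compounds go, it also remains open whether a step large enough to read would keep its size when moved from the core of compound 1 to the core of compound 3.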